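Ethoxy for Acetamido: What Compound 3 Should Tolerate

The source may hold more compounds than are shown below. What is called first, only, known or untested is meant among the compounds shown, and "the series" means these compounds.

Measured so far:
- compound 1, `COCCNc1nc(F)c(-c2nn(Cc3ccc(C#N)cc3)c(=O)c3ccccc23)cc1Cl`, in this assay a limit of > 100000 nM
- compound 2, `CC(=O)Nc1ccc(-c2nn(Cc3ccc(C#N)cc3)c(=O)c3ccccc23)c(F)n1`, in this assay a limit of > 100000 nM

Both values come from an ADME assay on HepG2 2.2.15 cells (Homo sapiens) for cytotoxicity, read by MTT assay, with a stated time of 8 days (a lower number here means that less compound is tolerated, a higher number that more compound is tolerated), and neither is a number. Compound 1 reaches only the limit > 100000 nM in this assay. Compound 2 likewise gives only the limit > 100000 nM in this assay. Compound 2 therefore stands at the limit of > 100000 nM in this assay, at which 2 of the 2 values shown sit, and nothing more precise can be said of where it sits; no difference between the two measured compounds can be read, since both stop at the same limit.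

Compound 3, `CCOc1ccc(-c2nn(Cc3ccc(C#N)cc3)c(=O)c3ccccc23)c(F)n1`, is not yet measured. It differs from compound 2 in one place: ethoxy in place of acetamido on an aromatic carbon. Within the data shown here, since no step between measured compounds is available, the size of the step can only be guessed; the change is small, and the step that the limit leaves unreadable from compound 2 to compound 3 is expected to be none beyond the usual scatter in this assay. Compound 3 is accordingly expected to give 150000 nM, with a range from 50000 nM to 500000 nM, and most likely to be reported again only as a limit.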

Compound 3, half-maximal cytotoxic concentration: > 100000 nM
Compound 3 gave a limit, no number (the forecaster's own chance of this, stated with the estimate: 85%); the middle value is on the limit's open side.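

No step can be read from compound 2 to compound 3, as compound 3, like compound 2, gives only a limit in this assay, not a number: the limit of > 100000 nM in this assay, at which 3 of the 3 values shown sit.

The compounds shown leave open where the half-maximal cytotoxic concentration of any of the three lies, and whether ethoxy in place of acetamido shifts it at all.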